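From Hydroxymethyl to Fluoromethyl: An Expected Gain in Cytotoxicity

The compounds below may be only part of what the source reports. "The series", "measured", "known", "first", "only" and "open" are said of these compounds alone.

Measured in a functional assay on HL-60 cells (Homo sapiens) for cytotoxicity, read by WST assay, with a stated time of 48 h; on this read-out higher numbers stand for weaker inhibition and lower numbers for stronger inhibition:
- Compound 1 `COc1cc(C(c2ccc(O)c(OC)c2)[C@H](CC(C)C)C(C)C)ccc1O`: 9600 nM
- Compound 2 `COc1cc(C(c2ccc(O)c(OC)c2)[C@H](CO)C(C)C)ccc1O`: > 100000 nM

Compound 2 stands at the limit of > 100000 nM in this assay, at which 1 of the 2 values shown sits, so its result is a limit and not a number. Compound 3 `COc1cc(C(c2ccc(O)c(OC)c2)[C@@H](CF)C(C)C)ccc1O` has not yet been measured. It carries 1-(fluoromethyl)-2-methylpropyl in place of 1-(hydroxymethyl)-2-methylpropyl on a saturated chain carbon bound to two aromatic carbons.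

Within the data shown here, one measured step bears on this change: an at least 10-fold higher number from compound 1 to compound 2 (1.01 log units; beyond the scatter). This large step, beyond the scatter, put hydroxy in place of isopropyl. Compound 3 has no hydroxy, so part of that step is expected to reverse in this assay, giving a lower number. Among the measured compounds shown here, a full return is not expected, since fluoromethyl is a different group from the one in compound 1. As far as these compounds go, the expected change is an at least 3.3-fold lower number from compound 2 to compound 3 (0.52 log units; beyond the scatter), towards stronger inhibition, and its exact size stays open. For compound 3, the estimated value is 30000 nM, with an expected range from 9000 nM to 100000 nM.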

Compound 3, half-maximal inhibitory concentration: 39000 nM
For compound 3 the middle estimate is 1.3-fold (0.11 log units) below the measured one; the range from low to high includes it.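

In this assay, 1-(fluoromethyl)-2-methylpropyl in place of 1-(hydroxymethyl)-2-methylpropyl on a saturated chain carbon bound to two aromatic carbons gives an at least 2.5-fold lower number from compound 2 to compound 3 (0.40 log units; beyond the scatter), so a measurable number returns at this position with a group that has 0 hydrogen-bond donors and keeps the same count of heavy atoms. Compound 2 has only a limit, so this step has a floor and no exact size: the limit of > 100000 nM in this assay, at which 1 of the 3 values shown sits. The return is only partial, as the comparison with the larger 1-isopropyl-3-methylbutyl group shows a 4.1-fold higher number from compound 1 to compound 3 (0.61 log units; beyond the scatter), and compound 1 therefore keeps the lower number of the two.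

The compounds shown leave open whether the gain belongs to fluoromethyl itself or would come with any group lacking the hydroxy, such as a plain methyl, a chloromethyl or a methoxymethyl. They also leave open how the number moves between fluoromethyl and the isobutyl arm of compound 1, where a longer chain such as ethyl or propyl, or a charged aminomethyl, would show whether size or the nature of the group sets it.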